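A third methoxy on a chalcone-pyrazole pair

A few compounds are considered here, and "the series" means these few. Any claim that something is new, unique, unknown or untested is made for them only; others in the source may bear on it.

Compound 1 `COc1ccc(-c2cc(/C=C/C(=O)c3ccc(N)cc3)[nH]n2)cc1` and compound 3 `COc1ccc(-c2cc(/C=C/C(=O)c3ccc(N)cc3)[nH]n2)cc1OC` share one core; compound 2 `COc1ccc(C(=O)/C=C/c2cc(-c3cc(OC)c(OC)c(OC)c3)n[nH]2)cc1OC` and compound 4 `COc1cc(C(=O)/C=C/c2cc(-c3cc(OC)c(OC)c(OC)c3)n[nH]2)cc(OC)c1OC` share another, and the difference between the two cores is not broken down here. In a functional assay on OVCAR-8 cells (Homo sapiens) for cytotoxicity, read by sulforhodamine B assay, with a stated time of 48 h, tested at 100 uM (on this read-out lower numbers stand for a stronger effect and higher numbers for a weaker effect at the one concentration tested), compound 1 gives -41%, while compound 3 gives -86%, a step of a number 45 percentage points lower from compound 1 to compound 3 (beyond the scatter) made by methoxy in place of hydrogen on an aromatic carbon. In this assay compound 2 gives -96%. Compound 4 carries the same kind of change on its core, (methoxy in place of hydrogen on an aromatic carbon), the place here being also meta to a methoxy group. A step of a number 1 percentage points lower from compound 2 to compound 4 (within the scatter) is expected because the earlier change gave a number 45 percentage points lower from compound 1 to compound 3 (beyond the scatter). That step is expected to stay small since compound 2 already gives -96%. Compound 4 is therefore estimated at -97% in this assay.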

Compound 4, a percentage reported as activity, at one concentration (the size of the read-out at that concentration, not a potency): -99%
Estimate against measurement, compound 4: 2 percentage points above, and the stated range covers the measured number.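

In this assay, methoxy in place of hydrogen on an aromatic carbon did not give a step of the same size on the two cores: the same change on two cores in this assay, a number 45 percentage points lower (beyond the scatter) from compound 1 to compound 3 and a number 3 percentage points lower (within the scatter) from compound 2 to compound 4, 42 percentage points apart, beyond the scatter of two such steps On the second core the step is a number 3 percentage points lower from compound 2 to compound 4 (within the scatter), so the large step seen on the first core did not carry over to this pair. These two pairs do not show why the steps differ, as the two cores differ in more than one place, and they support no general rule for the series.

The compounds shown leave open whether an ethoxy or a hydroxyl group in the same place would give a larger step on either core. They also leave open how compound 2 and compound 4 would compare at other concentrations.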